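The source may hold more compounds than are shown below. What is called first, only, known or untested is meant among the compounds shown, and "the series" means these compounds.

Measured in a functional assay on NCI-H460 cells (Homo sapiens) for cytotoxicity, read by MTT assay, with a stated time of 72 h; a higher number here means a weaker inhibitor, a lower number a stronger inhibitor:
Compound 1 `CC1CCN(Cc2ccc3nc(NC(=O)N/N=C/c4cn(Cc5ccc(Cl)cc5Cl)c5ccccc45)sc3c2)CC1`: 1660 nM
Compound 2 `CCN(CC)Cc1ccc2nc(NC(=O)N/N=C/c3cn(Cc4ccc(Cl)cc4Cl)c4ccccc34)sc2c1`: 1080 nM
Compound 3 `CCN(CC)Cc1ccc2nc(NC(=O)N/N=C/c3cn(Cc4ccc(C)cc4)c4ccccc34)sc2c1`: 320 nM

Compound 1 sits at the upper end of this small set, but it cannot be separated from compound 2: the change of amine gives a 1.5-fold lower number from compound 1 to compound 2 (0.19 log units; within the scatter). Compound 3, at 320 nM, lies clearly lower than both.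

The unmeasured compound 4 `CC1CCN(Cc2ccc3nc(NC(=O)N/N=C/c4cn(Cc5ccc(C(C)(C)C)cc5)c5ccccc45)sc3c2)CC1` keeps the 4-methylpiperidin-1-yl group of compound 1 and differs elsewhere: 4-(tert-butyl)phenyl in place of 2,4-dichlorophenyl on a saturated chain carbon bound to an aromatic nitrogen. The most relevant evidence is the other measured change at this place, on a saturated chain carbon bound to an aromatic nitrogen. There, 4-methylphenyl in place of 2,4-dichlorophenyl gave a 3.4-fold lower number from compound 2 to compound 3 (0.53 log units; beyond the scatter). For the measured compounds named here, that step was seen with the diethylamino group, and no measured compound carries 4-(tert-butyl)phenyl, so it is only a guide. The amine step, a 1.5-fold lower number from compound 1 to compound 2 (0.19 log units; within the scatter), gives no reason to expect a very different outcome with 4-methylpiperidin-1-yl. A modest move to a lower number is therefore expected in this assay, probably somewhat smaller than the step to compound 3. The expected change is a 2.8-fold lower number from compound 1 to compound 4 (0.44 log units; beyond the scatter). For compound 4 the estimated value is 600 nM, with an expected range from 220 nM to 1500 nM.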

Compound 4, half-maximal inhibitory concentration: 3370 nM
Compound 4: the middle estimate sits 5.6-fold (0.75 log units) below what was measured; the whole stated range lies below it.
By their numbers in this assay, from the lowest: compound 3; then compounds 2 and 1 (each within the scatter of the next); then compound 4.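

In this assay, the change to 4-(tert-butyl)phenyl gives a 2.0-fold higher number from compound 1 to compound 4 (0.31 log units; beyond the scatter), which runs opposite to the earlier step at this place on a saturated chain carbon bound to an aromatic nitrogen, where 4-methylphenyl gave a 3.4-fold lower number from compound 2 to compound 3 (0.53 log units; beyond the scatter). The departure of 2,4-dichlorophenyl therefore does not by itself bring a lower number: both entering groups replace the same dichlorinated ring, yet the outcome depends on which group enters, on the amine it is paired with, or on both. The two steps were seen with different amines, 4-methylpiperidin-1-yl and diethylamino, and nothing given here accounts for their opposite directions.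

The compounds shown do not separate the entering group from the amine, so it remains open whether 4-(tert-butyl)phenyl would also raise the number alongside diethylamino, or whether 4-methylphenyl would lower it alongside 4-methylpiperidin-1-yl. Also open, on these data alone, is how an unsubstituted phenyl or a methoxyphenyl would behave at this place, and whether a morpholine in place of either amine would alter the picture in this assay.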